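Ester to acid on the side chain of compound 2

The source may report more compounds than this note shows. Statements on the series, on what has been measured and on what is new or still open speak of the compounds shown alone.

Compounds measured so far:
- compound 2 `CCOC(=O)CCCCOc1ccc2c(=O)c(-c3ccc(O)cc3)coc2c1`
- compound 1 `O=C(O)COc1ccc(-c2coc3cc(OCC(=O)O)ccc3c2=O)cc1`

In an assay (Cricetulus griseus) for inhibition of aldehyde dehydrogenase, mitochondrial (Homo sapiens) (a higher number here means a weaker inhibitor, a lower number a stronger inhibitor), compound 2 gives 240 nM. Among the compounds with values here, this is the only number in the set. For compound 1 the result is a limit of the assay rather than a number, >> 9000 nM, as noted in the limit of >> 9000 nM in this assay, at which 1 of the 2 values shown sits. So compound 2 stands alone as the one compound with a measured strength here, and no step between two measured compounds can be drawn.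

Compound 3 `O=C(O)COc1ccc2c(=O)c(-c3ccc(O)cc3)coc2c1` has not yet been measured in this assay. It is made from compound 2 by one change: carboxy in place of 3-(ethoxycarbonyl)propyl on a saturated chain carbon bound to an oxygen on an aromatic ring. The shared core and the phenol on the other side stay as they are; only the chain on the aromatic oxygen is shortened and its ethyl ester becomes a free acid.

The expectation rests on compound 1, which carries the same carboxymethyl group and sits at the limit in this assay. A loss of strength beyond the usual scatter is expected, with the step from compound 2 to compound 3 estimated as a 21-fold higher number from compound 2 to compound 3 (1.32 log units; beyond the scatter). Compound 3 is therefore expected to give about 5000 nM, within a range of 1000 nM to 30000 nM.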

Compound 3, half-maximal inhibitory concentration: 1200 nM
The estimate for compound 3 lay 4.2-fold (0.62 log units) above the measured number, within the range that was stated.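

In this assay, the change on the saturated chain carbon bound to an oxygen on an aromatic ring gives a 5.0-fold higher number from compound 2 to compound 3 (0.70 log units; beyond the scatter), so replacing 3-(ethoxycarbonyl)propyl with carboxy costs strength, yet a measurable number remains. Compound 1 gives no number, only a limit of the assay: the limit of >> 9000 nM in this assay, at which 1 of the 3 values shown sits. Hydrogen in place of carboxymethyl on an oxygen on an aromatic ring gives an at least 7.5-fold lower number from compound 1 to compound 3 (0.87 log units; beyond the scatter), so the carboxymethyl group that compound 3 shares with compound 1 is not enough by itself to take a compound to that limit, and the second carboxymethyl group matters as well.

The step to compound 3 shortens the chain and turns the ethyl ester into a free acid in one move, and the compounds shown cannot tell how much of the loss belongs to each part. A free carboxylic acid on the longer chain, an ethyl ester on the short chain, or an amine at the end of the chain would each help to pull these two parts apart.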